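A few compounds are considered here, and "the series" means these few. Any claim that something is new, unique, unknown or untested is made for them only; others in the source may bear on it.

Among the compounds with values here, compound 2 `CNc1ncc(C#Cc2ccc(C)cc2)cn1` is the one compound with a numerical result: in an assay on HEK293 cells for positive allosteric modulation of metabotropic glutamate receptor 5 (Rattus norvegicus) (a higher number here means that more compound is needed for the effect, a lower number that less compound is needed), compound 2 gives 704000 nM. Compound 1 `Cc1ncc(C#Cc2ccccc2)cn1` was recorded in this assay as "not active" (no number reported). Compound 3 `Cc1ccc(C#Cc2cnc(C)nc2)cc1` keeps the shared core and differs from compound 2 by methyl in place of methylamino on an aromatic carbon. Within the data shown here, with no measured pair of this kind to lean on, the expected step in this assay from compound 2 to compound 3 is toward a larger number, probably beyond the usual scatter, because the exchanged group takes compound 3 closer to compound 1 with its "not active" (no number reported) outcome; the estimated step is a 2.1-fold higher number from compound 2 to compound 3 (0.33 log units; beyond the scatter). For compound 3 the estimated value in this assay is 1500000 nM, within 400000 nM to 6000000 nM.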

Compound 3, half-maximal effective concentration: "not active" (no number reported)
The entry for compound 3 holds no number; there is nothing to compare the estimate with.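

Within the data shown here, compound 3 carries no number, so no step from compound 2 to compound 3 can be read. The compounds shown leave open how far methyl in place of methylamino shifts the result in this assay. Nothing shown speaks to a cause for this outcome.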